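The source may report more compounds than this note shows. Statements on the series, on what has been measured and on what is new or still open speak of the compounds shown alone.

In an ADME assay on microsomes from liver (Homo sapiens) for metabolic stability, read by LC-MS, with a stated time of 10 min, tested at 0.5 uM (a lower number here means that less of the compound is left, a higher number that more of the compound is left), the measured compounds read:
Compound 1 `c1ccc2c(c1)CN[C@@H](CN(CCCN1CCNCC1)[C@H]1CCCc3cccnc31)C2` gives 100%
Compound 2 `c1ccc2c(c1)CN[C@@H](CN(CCC1CCNCC1)[C@H]1CCCc3cccnc31)C2` gives 66%
Compound 3 `c1cnc2c(c1)CN[C@H](CN(CCCN1CCNCC1)[C@H]1CCCc3cccnc31)C2` gives 100%

Compound 2 stands lowest of the three, beyond the scatter from both others. Compound 4 `c1ccc2c(c1)CN[C@@H](CN(CCN1CCNCC1)[C@H]1CCCc3cccnc31)C2` differs from compound 2 by one change (piperazin-1-yl in place of piperidin-4-yl on a saturated chain carbon, two bonds along the chain from an amine nitrogen), with piperazin-1-yl in place of piperidin-4-yl on a saturated chain carbon. Where piperidin-4-yl replaces (piperazin-1-yl)methyl, the data show a number 34 percentage points lower from compound 1 to compound 2 (beyond the scatter) and this large step bears most. The change elsewhere shows no change at the digits printed from compound 1 to compound 3 (within the scatter) and bears little. Compound 4 restores the piperazin-1-yl but not the (piperazin-1-yl)methyl, so a rise in this assay is expected, probably smaller than that large step. This estimate means a number 22 percentage points higher from compound 2 to compound 4 (beyond the scatter) as the expected step. For compound 4 the estimated value is 88% within an expected range of 70% to 100% in this assay.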

Compound 4, percent of the compound remaining: 96%
Estimate against measurement, compound 4: 8 percentage points below, within the range that was stated.
By their numbers in this assay, from the lowest: compound 2; then compounds 4, 1 and 3 (each within the scatter of the next).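

In this assay, the ring alone accounts for a clear difference at this position: piperazin-1-yl in place of piperidin-4-yl gives a number 30 percentage points higher from compound 2 to compound 4 (beyond the scatter). Piperazin-1-yl in place of (piperazin-1-yl)methyl gives a number 4 percentage points lower from compound 1 to compound 4 (within the scatter), so the extra methylene shows no effect here, and the low number of compound 2 goes with piperidin-4-yl. No evidence is available on why the two rings differ. The compounds shown leave open how a morpholin-4-yl at this place, or a 4-(piperazin-1-yl)butyl chain, would read.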